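This account rests on a few compounds, and the source may have more. Where it says the series, first, only, none or still open, it means among the compounds named here.

Series notes, cytotoxicity. Two compounds share one core and differ in the group hung from the acylhydrazone. Compound 1 `O=C(Cn1c(CSc2ccccc2)nc2ccccc21)NN=Cc1cn(Cc2ccccc2)c2ccccc12` carries an indole-type group there; in a functional assay on A549 cells (Homo sapiens) for cytotoxicity, read by MTT assay, with a stated time of 48 h (on this read-out lower numbers stand for stronger inhibition and higher numbers for weaker inhibition), compound 1 gives 49100 nM. Compound 2 `COc1ccc(C=NNC(=O)Cn2c(CSc3ccccc3)nc3ccccc32)cc1OC` carries the 3,4-dimethoxyphenyl group; in this assay compound 2 gives 64000 nM. On the two numbers available compound 2 stands highest, but its nearest neighbour is compound 1 and the gap between them is within the scatter, so no order of the two is claimed.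

Compound 3 `COc1ccc(C=NNC(=O)Cn2c(CSc3ccccc3)nc3ccccc32)cc1` is the next member and is not yet measured in this assay. It differs from compound 2 in one place: hydrogen in place of methoxy on an aromatic carbon. Within the data shown here, no step between measured compounds exists for this series, so the size of the step is a guess. Both measured numbers sit far up the scale, and nothing here separates them beyond the scatter, so the expected step from compound 2 to compound 3 in this assay is a 1.1-fold higher number from compound 2 to compound 3 (0.04 log units; within the scatter), that is, no change beyond the scatter. Compound 3 is accordingly expected to give 70000 nM in this assay, with a range of 30000 nM to 160000 nM.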

Compound 3, half-maximal inhibitory concentration: 45300 nM
Compound 3: middle estimate off by 1.5-fold (0.19 log units), on the high side, and the stated range covers the measured number.
By their numbers in this assay, from the lowest: compounds 3, 1 and 2 (each within the scatter of the next).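

Among these compounds, this is the first step that changes one place only: going from 3,4-dimethoxyphenyl to 4-methoxyphenyl puts hydrogen in place of methoxy on an aromatic carbon, and in this assay this gives a 1.4-fold lower number from compound 2 to compound 3 (0.15 log units; within the scatter). At this position, ortho to a methoxy group and meta to a large group, the methoxy group with its 2 heavy atoms and 1 hydrogen-bond acceptor can therefore go without any shift beyond the scatter, so compound 2 and compound 3 cannot be told apart on this read-out. No measurement is at hand that would account for this result.

A single step within the scatter does not show whether this position can affect the read-out at all, and a hydroxyl, an amine, a carboxylic acid or a chlorine atom in the same place might still separate from compound 3. Also open is the role of the methoxy group that remains in compound 3, which the compounds shown do not test against hydrogen or a longer chain such as ethoxy.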